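Replacing 3-bromophenyl in compound 2: glucuronidation half-life

This account rests on a few compounds, and the source may have more. Where it says the series, first, only, none or still open, it means among the compounds named here.

Measured compounds:
compound 1 `NS(=O)(=O)CC(=O)NCCSc1nonc1/C(=N/O)Nc1cccc(Cl)c1`: 0.9 h
compound 2 `NS(=O)(=O)CC(=O)NCCSc1nonc1/C(=N/O)Nc1cccc(Br)c1`: 0.955 h
compound 3 `NS(=O)(=O)NCCSc1nonc1/C(=N/O)Nc1ccc(F)c(Br)c1`: 0.183 h

In an ADME assay on isolated protein for pharmacokinetics, with UDP-glucuronosyltransferase 1A9 (Homo sapiens) as the target, read by LC-MS, with a stated time of 60 min, at 37 degrees C, tested at 1 uM, in the presence of a further agent that is not named here (a lower number here means that the compound disappears faster, a higher number that the compound lasts longer), compound 2 gives 0.955 h, the highest of the three numbers. Its separation from compound 1 is only a 1.1-fold higher number from compound 1 to compound 2 (0.03 log units; within the scatter), within the scatter, so the two are not distinguished. For the measured compounds named here, compound 3 differs from compound 2 in two places and is the only number beyond the scatter from it.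

Compound 4 `N#Cc1cc(N/C(=N\O)c2nonc2SCCNC(=O)CS(N)(=O)=O)ccc1F` differs from compound 2 by 3-cyano-4-fluorophenyl in place of 3-bromophenyl on an amine nitrogen. Going by the values given here, no measured step covers a nitrile or a second substituent on this ring; the single step available, a 1.1-fold higher number from compound 1 to compound 2 (0.03 log units; within the scatter), shows only that a halogen swap leaves the number within the scatter. No step beyond the scatter is therefore expected. Compound 4 is expected to give about 1 h, with a range of 0.45 h to 2.2 h. The expected step is a 1.0-fold higher number from compound 2 to compound 4 (0.02 log units; within the scatter).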

Compound 4, half-life: > 3 h
Compound 4 was reported as a limit (the forecaster's own chance of this, stated with the estimate: 5%); middle value at least 3.0-fold (0.47 log units) away from the limit.
By their numbers in this assay, from the lowest: compound 3; then compounds 1 and 2 (each within the scatter of the next). At a limit, above all of these: compound 4.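

The aryl group on this amine nitrogen does change the number: 3-cyano-4-fluorophenyl in place of 3-bromophenyl gives an at least 3.1-fold higher number from compound 2 to compound 4 (0.49 log units; beyond the scatter) and in place of 3-chlorophenyl gives an at least 3.3-fold higher number from compound 1 to compound 4 (0.52 log units; beyond the scatter). The halogen swap alone had given only a 1.1-fold higher number from compound 1 to compound 2 (0.03 log units; within the scatter). In this assay, on these data alone, compound 4 stands as a limit and not a number, so the full size of both steps stays unknown: the limit of > 3 h in this assay, at which 1 of the 4 values shown sits.

The compounds shown do not separate the nitrile from the fluorine in compound 4. As far as these compounds go, how 3-cyanophenyl alone, or a carboxylic acid in place of the nitrile, would read also stays open.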